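The source may hold more compounds than are shown below. What is called first, only, known or untested is meant among the compounds shown, and "the series" means these compounds.

Measured compounds:
compound 1 `COc1ccccc1CSc1nc2cc(NC(=O)C3CC3)ccc2n1C(C)C`: > 10000 nM
compound 2 `CC(C)n1c(SCc2ccccc2Cl)nc2cc(NC(=O)C3CC3)ccc21`: > 10000 nM
compound 3 `CCn1c(SCc2cc([N+](=O)[O-])ccc2OC)nc2cc(NC(=O)NC(C)(C)C)ccc21`: 170 nM

In an assay on isolated protein for inhibition of Gonadotropin-releasing hormone receptor (Rattus norvegicus) (on this read-out higher numbers stand for weaker inhibition and lower numbers for stronger inhibition), compound 1 gives > 10000 nM, which is a limit of the assay and not a number. Compound 2 likewise gives only a limit, > 10000 nM. The step from compound 1 to compound 2 is therefore a step that the two limits leave unreadable from compound 1 to compound 2; both of its ends sit at the limit of > 10000 nM in this assay, at which 2 of the 3 values shown sit, so its size cannot be read. For the measured compounds named here, compound 3 is the one compound of the three with a measured number, 170 nM, and so it stands alone as the only fixed point in this assay.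

Compound 4 `COc1ccc([N+](=O)[O-])cc1CSc1nc2cc(NC(=O)NC(C)(C)C)ccc2n1Cc1ccccn1` differs from compound 3 in one place: pyridin-2-yl in place of methyl on a saturated chain carbon bound to an aromatic nitrogen. Going by the values given here, no measured pair in the set changes this part of the core; the single measured step concerns a substituent on the benzyl ring and is unreadable anyway. Nothing in the data therefore speaks for a shift in either direction, and the expectation for this assay is a step no larger than the usual scatter: compound 4 is estimated to lie close to compound 3, the step from compound 3 to compound 4 being no change at the digits printed from compound 3 to compound 4 (within the scatter). On that basis compound 4 is expected to give about 170 nM in this assay, within a range from 50 nM to 600 nM.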

Compound 4, half-maximal inhibitory concentration: 670 nM
The estimate for compound 4 lay 3.9-fold (0.60 log units) below the measured number, outside the stated range (above it).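

In this assay, for the compounds shown here, the change of methyl to pyridin-2-yl on a saturated chain carbon bound to an aromatic nitrogen gives a 3.9-fold higher number from compound 3 to compound 4 (0.60 log units; beyond the scatter) and so provides the first readable step, modest in size but beyond the scatter. The position therefore responds to this change, yet with the six heavy atoms of pyridin-2-yl in place compound 4 still gives 670 nM and not a limit of the assay. Nothing measured in the series accounts for the direction or size of this step.

A phenyl group on the same carbon would separate the effect of the ring from that of its nitrogen, while pyridin-3-yl and pyridin-4-yl groups would test whether the place of that nitrogen matters. Also open, from the compounds shown here alone, are how an amine or a longer alkyl chain at this position would compare with methyl, and whether the step carries over to compound 1 and compound 2, which both sit at a limit of the assay and leave the step between them unreadable.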